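From Methoxy to Phenylsulfonyl on the Shared Core

The source may report more compounds than this note shows. Statements on the series, on what has been measured and on what is new or still open speak of the compounds shown alone.

In a functional assay on U-373MG ATCC cells (Homo sapiens) for inhibition, read by colorimetric assay and MTT assay, with a stated time of 72 h (a lower number here means a stronger inhibitor, a higher number a weaker inhibitor), compound 1 (`C=CCCCCCOc1ncc(-c2ccccc2OCCCCC=C)n1C`) gives 76000 nM. Compound 2 (`C=CCCCCOc1ccccc1-c1cnc(OC)n1C`) gives > 100000 nM, which is a limit and not a number. Within the data shown here, the only measured step, an at least 1.3-fold higher number from compound 1 to compound 2 (0.11 log units; that floor lies within the scatter), concerns the chain on the oxygen and offers little guidance for the new change. Compound 3 (`C=CCCCCOc1ccccc1-c1cnc(S(=O)(=O)c2ccccc2)n1C`) carries phenylsulfonyl in place of methoxy on an aromatic carbon, between two ring nitrogen atoms: phenylsulfonyl in place of methoxy on an aromatic carbon. A modest move towards a lower number is expected, an at least 1.6-fold lower number from compound 2 to compound 3 (0.22 log units; that floor lies within the scatter). For compound 3 the estimated value is 60000 nM, with an expected range of 15000 nM to 150000 nM.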

Compound 3, half-maximal inhibitory concentration: 63000 nM
Compound 3: middle estimate off by 1.1-fold (0.02 log units), on the low side, within the range that was stated.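

In this assay, phenylsulfonyl on the aromatic carbon between two ring nitrogen atoms gives a measured number where methoxy gave only a limit, and an at least 1.5-fold lower number from compound 2 to compound 3 (0.20 log units; that floor lies within the scatter) is all that can be read of that change. With phenylsulfonyl in place of (hept-6-en-1-yl)oxy at the same carbon, a 1.2-fold lower number from compound 1 to compound 3 (0.08 log units; within the scatter) also separates nothing, so this position shows no step beyond the scatter. The reading for compound 2 remains a limit, not a number: the limit of > 100000 nM in this assay, at which 1 of the 3 values shown sits. As far as these compounds go, whether an amine or a carboxylic acid on this aromatic carbon would move the number beyond the scatter stays open.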